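Biaryl replacement and lipophilicity: notes on compound 3

The source may report more compounds than this note shows. Statements on the series, on what has been measured and on what is new or still open speak of the compounds shown alone.

Measured so far:
compound 1 `CC[C@H](Nc1c(C#N)c(-c2ccc(Br)cc2)nc2cnccc12)C(N)=O` — 2.3
compound 2 `CC[C@@H](Nc1c(C#N)c(-c2ccc(-c3ccc(F)cc3)cc2)nc2cnccc12)C(N)=O` — 2.7

In a physicochemical assay for lipophilicity, read by HPLC, at pH 7.5 (on this read-out lower numbers stand for lower lipophilicity and higher numbers for higher lipophilicity), compound 2 gives 2.7, the higher of the two numbers. Compound 1 gives 2.3, lower by a gap beyond the scatter. Compound 3 `CC[C@@H](Nc1c(C#N)c(-c2ccc(-c3ccccc3C(F)(F)F)cc2)nc2cnccc12)C(N)=O` differs from compound 2 by 2-(trifluoromethyl)phenyl in place of 4-fluorophenyl on an aromatic carbon. Among the compounds with values here, no measured pair shows this change, so the step must be judged from the structures alone: a group of more heavy atoms and three fluorines enters where one of fewer atoms and one fluorine leaves. The expected step is a number 0.60 log units higher from compound 2 to compound 3 (beyond the scatter), upward and beyond the scatter. For compound 3 the estimate is 3.3, within 2.9 to 3.8.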

Compound 3, distribution coefficient: 3.1
The estimate for compound 3 lay 0.20 log units above the measured number, and the stated range covers the measured number.
By their numbers in this assay, from the lowest: compound 1; then compound 2; then compound 3.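

In this assay, within the data shown here, the first measured step at this position is a number 0.40 log units higher from compound 2 to compound 3 (beyond the scatter), with 2-(trifluoromethyl)phenyl in place of 4-fluorophenyl. The number here therefore changes with the group carried on this aromatic carbon, even though neither group has hydrogen-bond donors, hydrogen-bond acceptors or a net charge. No supporting measurement bears on the origin of this step.

On these data alone, it remains open whether the step follows the trifluoromethyl group itself or the different substitution on the ring. Also open, as far as these compounds go, is where a phenyl carrying an amine or a carboxylic acid would fall.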